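This account rests on a few compounds, and the source may have more. Where it says the series, first, only, none or still open, it means among the compounds named here.

In a functional assay on HCT-8 cells (Homo sapiens) for antiproliferative activity, read by MTT assay, with a stated time of 48 h (on this read-out higher numbers stand for weaker inhibition and lower numbers for stronger inhibition), two compounds have been measured so far:

Compound 1 `COc1ccc(C(=O)c2ccc(OC)c3c2C=CC(C)(C)O3)c(NC(=O)CO)c1` gives 630 nM
Compound 2 `C=C(c1ccc(OC)cc1NC(=O)CO)c1ccc(OC)c2c1OC(C)(C)C=C2` gives 130 nM

Compound 2 with 130 nM holds the lower of the two numbers, and compound 1 with 630 nM lies above it by more than the usual scatter. Compound 3 `C=C(c1ccc(OC)cc1NC(=O)CN(C)C)c1ccc(OC)c2c1OC(C)(C)C=C2` differs from compound 2 in one place: dimethylamino in place of hydroxy on a saturated chain carbon bound to a carbonyl carbon. Within the data shown here, no measured pair shows this change, so in this assay only a small rise in the number, probably within the scatter, is expected (a 1.5-fold higher number from compound 2 to compound 3 (0.19 log units; within the scatter)). Compound 3 is estimated at 200 nM (expected range 50 nM to 800 nM).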

Compound 3, half-maximal inhibitory concentration: 690 nM
The estimate for compound 3 lay 3.5-fold (0.54 log units) below the measured number; the measured number falls inside the stated range.
By their numbers in this assay, from the lowest: compound 2; then compounds 1 and 3 (each within the scatter of the next).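

In this assay, this saturated chain carbon bound to a carbonyl carbon proves sensitive to what it carries: dimethylamino in place of hydroxy gives a 5.3-fold higher number from compound 2 to compound 3 (0.72 log units; beyond the scatter) and so weakens inhibition. No measurement shown explains this step.

The compounds shown leave open whether the weaker inhibition follows from removing the hydroxy or from introducing the dimethylamino, since this single pair changes both at once. A methoxy group or a primary amine at the same place would bear on that question, as would a longer chain carrying the hydroxy.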